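Benzyl para substituent variation on a pyrimidine-fused core

A few compounds are considered here, and "the series" means these few. Any claim that something is new, unique, unknown or untested is made for them only; others in the source may bear on it.

Measured compounds:
compound 1 `CCCCNc1nc(N)nc2c1CN(C(=O)c1ccccc1)CC2`: 1.4 uM
compound 2 `CCCCNc1nc(N)nc2c1CN(Cc1ccc(OC)cc1)CC2`: 0.08 uM
compound 3 `CCCCNc1nc(N)nc2c1CN(Cc1ccc(OC(F)(F)F)cc1)CC2`: 0.24 uM

In an assay on HEK293 cells for agonist activity at Toll-like receptor 8 (Homo sapiens), read by a luciferase reporter, with a stated time of 6 h (on this read-out higher numbers stand for an effect only at larger amounts of compound and lower numbers for an effect already at smaller amounts), compound 3 stands second highest of the three numbers. Its nearest neighbour is compound 2, which gives 0.08 uM, a step of a 3.0-fold higher number from compound 2 to compound 3 (0.48 log units; beyond the scatter) away; furthest is compound 1 with 1.4 uM. Compound 4 `CCCCNc1nc(N)nc2c1CN(Cc1ccc(C(C)(C)C)cc1)CC2` is not yet measured. It differs from compound 3 by tert-butyl in place of trifluoromethoxy on an aromatic carbon. Among the compounds with values here, no measured step swaps a trifluoromethoxy for a tert-butyl; the only step at this aromatic carbon is the modest one from methoxy to trifluoromethoxy, a 3.0-fold higher number from compound 2 to compound 3 (0.48 log units; beyond the scatter). Compound 4 is therefore expected to sit close to compound 3, with a small step of a 1.3-fold higher number from compound 3 to compound 4 (0.10 log units; within the scatter) in this assay. The estimate for compound 4 is 0.3 uM, within a range from 0.08 uM to 1.2 uM.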

Compound 4, minimum effective concentration: 0.66 uM
Compound 4: middle estimate off by 2.2-fold (0.34 log units), on the low side; measured number inside the range.
By their numbers in this assay, from the lowest: compound 2; then compound 3; then compound 4; then compound 1.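

In this assay, tert-butyl on this aromatic carbon gives a higher number than either oxygen-linked group (a 2.8-fold higher number from compound 3 to compound 4 (0.44 log units; beyond the scatter); an 8.3-fold higher number from compound 2 to compound 4 (0.92 log units; beyond the scatter)). Both steps lie beyond the scatter, so the read-out at this position also changes when the group linked through oxygen gives way to one of carbon only, and among these three benzyl compounds, compound 2 keeps the lowest number. No evidence on the cause of these steps is at hand. Going by these compounds, whether an amine, a carboxylic acid or an ethoxy group here would give a number lower than that of compound 2 remains open.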